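The compounds below may be only part of what the source reports. "The series", "measured", "known", "first", "only" and "open" are said of these compounds alone.

Measured in an ADME assay on L1210/0 cells (Mus musculus) for cytotoxicity, with a stated time of 48 h; on this read-out higher numbers stand for weaker inhibition and lower numbers for stronger inhibition:
compound 1 `O=C1O/C(=C\Cn2cc(Br)c(=O)[nH]c2=O)C(OCc2ccccc2)=C1OCc1ccccc1`: 7500 nM
compound 2 `O=C1O/C(=C\Cn2cc(Cl)c(=O)[nH]c2=O)C(OCc2ccccc2)=C1OCc1ccccc1`: 12200 nM

With only these two numbers in hand, compound 2 has a single neighbour, and the gap to it is small: a 1.6-fold higher number from compound 1 to compound 2 (0.21 log units; within the scatter). Among the measured compounds shown here, the two values therefore give no order between the compounds, and neither can be called the better one.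

The next compound is compound 3 `O=C1O/C(=C\Cn2cc(I)c(=O)[nH]c2=O)C(OCc2ccccc2)=C1OCc1ccccc1`, which keeps the shared core of compound 2 and changes only the group on one aromatic carbon: iodo in place of chloro on an aromatic carbon. For the measured compounds named here, that same aromatic carbon carries bromo in compound 1, so the one measured step bears directly on this change. Going by the values given here, it is a single step, it lies within the scatter, and it covers only one exchange of this kind. The data hold no measurement for iodo at this carbon, so the expectation rests on that one step alone. No shift beyond the scatter is expected in this assay, and no firm direction can be drawn. The expected step is a 1.5-fold lower number from compound 2 to compound 3 (0.18 log units; within the scatter). Compound 3 is estimated at 8000 nM, with an expected range of 3500 nM to 18000 nM.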

Compound 3, half-maximal inhibitory concentration: 7500 nM
For compound 3 the middle estimate is 1.1-fold (0.03 log units) above the measured one; the measured number falls inside the stated range.
By their numbers in this assay, from the lowest: compounds 1, 3 and 2 (each within the scatter of the next).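

Iodo now joins chloro and bromo on this aromatic carbon in this assay, and the exchange of chloro for iodo gives a 1.6-fold lower number from compound 2 to compound 3 (0.21 log units; within the scatter) while the exchange of bromo for iodo gives no change at the digits printed from compound 1 to compound 3 (within the scatter). With the earlier exchange of bromo for chloro also within the scatter, the three compounds give no order among chloro, bromo and iodo at this carbon, and a third member of the series now supports what a single step could only suggest: among these three groups, the choice of group at this position makes no readable difference to the number. Nothing available here offers an explanation for how closely these values sit together.

On these data alone, all three compounds carry a halogen at this carbon, so it remains open whether hydrogen, a methyl group or an amine there would move the number beyond the scatter. The two benzyl ethers are also identical throughout, which leaves open what a free hydroxyl group or a longer alkyl chain in their place would do in this assay.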